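A Cyanophenyl Group Replaces Pyridin-3-yl

The source may report more compounds than this note shows. Statements on the series, on what has been measured and on what is new or still open speak of the compounds shown alone.

Measured so far in a functional assay on NCI-H460 cells (Homo sapiens) for inhibition, with a stated time of 72 h (on this read-out higher numbers stand for weaker inhibition and lower numbers for stronger inhibition), for two compounds:
- compound 1 `COc1ccc(S(=O)(=O)N2CCc3cccc(-c4ccc(N(C)C)cc4)c32)cc1` gives 556 nM
- compound 2 `COc1ccc(S(=O)(=O)N2CCc3cccc(-c4cccnc4)c32)cc1` gives 89.6 nM

Compound 2 holds the lower of the two numbers, and its gap to compound 1 lies beyond the scatter. The next structure, compound 3 `COc1ccc(S(=O)(=O)N2CCc3cccc(-c4ccc(C#N)cc4)c32)cc1` keeps the shared core and changes one group: 4-cyanophenyl in place of pyridin-3-yl on an aromatic carbon with 4-cyanophenyl in place of pyridin-3-yl on an aromatic carbon. For the measured compounds named here, one measured step bears on this change, a 6.2-fold lower number from compound 1 to compound 2 (0.79 log units; beyond the scatter) and it is modest in size and exchanges the group at the same place. That step ran from a substituted phenyl to pyridin-3-yl. Going by the values given here, compound 3 returns to a substituted phenyl, but with a different substituent, and no measured compound carries a nitrile, so this single step guides only loosely. A move toward a higher number in this assay is therefore expected, smaller than the measured step. The estimated change is a 2.5-fold higher number from compound 2 to compound 3 (0.39 log units; beyond the scatter) in that direction. Compound 3 is estimated at 220 nM with an expected range from 70 nM to 650 nM on this read-out.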

Compound 3, half-maximal inhibitory concentration: 29.5 nM
Compound 3: the middle estimate sits 7.5-fold (0.87 log units) above what was measured; the whole stated range lies above it.
By their numbers in this assay, from the lowest: compound 3; then compound 2; then compound 1.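

In this assay, a ring of carbon only at this position does not by itself raise the number, since 4-cyanophenyl in place of pyridin-3-yl gives a 3.0-fold lower number from compound 2 to compound 3 (0.48 log units; beyond the scatter). What the earlier pair could not separate now comes apart: with the phenyl ring kept, cyano in place of dimethylamino gives a 19-fold lower number from compound 1 to compound 3 (1.28 log units; beyond the scatter), so the substituent on that ring shifts the number strongly, and the two substituted phenyl compounds fall on either side of the pyridin-3-yl compound 2. No evidence is available on why the nitrile compound gives the lowest of the three numbers.

The compounds shown leave open where an unsubstituted phenyl group would fall relative to these three, and so whether the nitrile lowers the number, the dimethylamino group raises it, or both. They also leave open whether other groups on the same ring, such as a primary amide, a carboxylic acid or a methoxy group, would follow the nitrile or the dimethylamino group, and whether a nitrile added to the pyridin-3-yl ring would give a lower number still.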